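The source may hold more compounds than are shown below. What is called first, only, known or untested is meant among the compounds shown, and "the series" means these compounds.

Among the measured compounds shown here, compound 3 `Cn1cnnc1-c1cc(Oc2ccc(NC(=O)N/N=C/c3ccccc3)cc2F)ccn1` is the one member of the series with a definite number: in a functional assay on U-87MG ATCC cells (Homo sapiens) for cytotoxicity, read by MTT assay, with a stated time of 72 h (on this read-out lower numbers stand for stronger inhibition and higher numbers for weaker inhibition), compound 3 gives 36300 nM. Compound 1 `CN(C)CCn1cnnc1-c1cc(Oc2ccc(NC(=O)N/N=C/c3cc(Br)c(O)c(Br)c3)cc2F)ccn1` returns only a limit of the assay in this assay, > 100000 nM. Compound 2 `COc1ccc(/C=N/NC(=O)Nc2ccc(Oc3ccnc(-c4nncn4CCN(C)C)c3)c(F)c2)cc1O` likewise returns only a limit in this assay, > 100000 nM. For the measured compounds named here, the single step between measured compounds, a step that the two limits leave unreadable from compound 1 to compound 2, is unreadable because both values sit at the limit of > 100000 nM in this assay, at which 2 of the 3 values shown sit. Compound 4 `CN(C)CCn1cnnc1-c1cc(Oc2ccc(NC(=O)N/N=C/c3ccccc3)cc2F)ccn1` differs from compound 3 by (dimethylamino)methyl in place of hydrogen on a saturated chain carbon bound to an aromatic nitrogen. Going by the values given here, no measured step covers this change; compounds 1 and 2 carry the same 2-(dimethylamino)ethyl group as compound 4 but a different group on the carbon with the double bond to nitrogen, and each shows only a limit. The step expected is a 1.7-fold higher number from compound 3 to compound 4 (0.22 log units; within the scatter). Compound 4 is estimated at 60000 nM, between 20000 nM and 200000 nM.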

Compound 4, half-maximal inhibitory concentration: 2250 nM
Estimate against measurement, compound 4: 27-fold (1.43 log units) above; measured number outside the range, below it.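

In this assay, methyl giving way to 2-(dimethylamino)ethyl produces a 16-fold lower number from compound 3 to compound 4 (1.21 log units; beyond the scatter), so this place on the saturated chain carbon bound to an aromatic nitrogen strongly affects the read-out when the other end carries phenyl. With 2-(dimethylamino)ethyl held fixed, the group on the carbon with a double bond to nitrogen also counts: phenyl gives an at least 44-fold lower number from compound 2 to compound 4 (1.64 log units; beyond the scatter) and an at least 44-fold lower number from compound 1 to compound 4 (1.64 log units; beyond the scatter). Those two steps have no exact size because compounds 1 and 2 each give only a limit of the assay: the limit of > 100000 nM in this assay, at which 2 of the 4 values shown sit.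

Going by these compounds, whether 3-(dimethylamino)propyl, a longer chain, or a morpholine in place of the dimethylamino group would keep this lower number remains open.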